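A few compounds are considered here, and "the series" means these few. Any claim that something is new, unique, unknown or untested is made for them only; others in the source may bear on it.

Measured compounds:
Compound 1, `CNC(=O)c1cc(-c2ccc(F)cc2F)ccc1OC(C)=O`, gives 29.9% in a functional assay on the whole organism (strain Kunming) for inhibition, with Mus musculus as the target, in the writhing test, at a dose of 40 mg/kg by the oral route; on this read-out lower numbers stand for less inhibition and higher numbers for more inhibition at the one dose given (going by the name of the read-out).
Compound 2, `CC(=O)Oc1ccc(-c2ccc(F)cc2F)cc1C(=O)NCc1ccccc1`, gives 16.6% in this assay.

Compound 2 stands lowest of the two numbers, with the step of a number 13.3 percentage points lower from compound 1 to compound 2 (beyond the scatter) setting it apart from compound 1. Compound 3, `CC(=O)Oc1ccc(-c2ccc(F)cc2F)cc1C(=O)NN1CCOCC1`, differs from compound 2 by morpholin-4-yl in place of benzyl on an amide-type nitrogen. For the measured compounds named here, only the step from compound 1 to compound 2 touches the same amide-type nitrogen, and it shows that a change there can move the read-out by a modest amount. Since the benzyl that lowered the number now leaves, compound 3 is expected to rise by a number 8.4 percentage points higher from compound 2 to compound 3 (within the scatter), to an estimated 25% within 8% to 42%.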

Compound 3, a percentage reported as inhibition, in the whole organism at one dose (the size of the read-out at that dose, not a potency): 28.5%
Compound 3: middle estimate off by 3.5 percentage points, on the low side, and the stated range covers the measured number.
By their numbers in this assay, from the lowest: compound 2; then compounds 3 and 1 (each within the scatter of the next).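

In this assay, morpholin-4-yl in place of benzyl on the amide-type nitrogen gives a number 11.9 percentage points higher from compound 2 to compound 3 (beyond the scatter), so a ring on this nitrogen does not by itself bring the low number of compound 2. Morpholin-4-yl in place of methyl gives a number 1.4 percentage points lower from compound 1 to compound 3 (within the scatter), so these two groups cannot be told apart here. Nothing available explains why benzyl and morpholin-4-yl differ.

Still open, on these data alone, is whether piperidin-1-yl, the same ring with carbon in place of its oxygen, would match morpholin-4-yl. A longer chain such as butyl on this nitrogen is also untested among these compounds.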